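The compounds below may be only part of what the source reports. "The series", "measured", "known", "first", "only" and "open" are said of these compounds alone.

The measured compounds:
Compound 1, `N#CC1=C(N)Oc2c(c3nc4ccccc4nc3c3ccccc23)C12C(=O)N(Cc1cnnn1-c1cccc(Cl)c1)c1ccccc12`, reaches only a limit in a functional assay on HCT-116 cells (Homo sapiens) for antiproliferative activity, read by MTT assay, with a stated time of 48 h; a higher number here means a weaker inhibitor, a lower number a stronger inhibitor; compound 1 gives > 50000 nM.
Compound 2, `N#CC1=C(N)Oc2c(c3nc4ccccc4nc3c3ccccc23)C12C(=O)N(Cc1cnnn1-c1ccc(N)cc1)c1ccccc12`, gives 45200 nM in this assay.
Compound 3, `CCOc1ccc(-n2nncc2CN2C(=O)C3(C(C#N)=C(N)Oc4c(N)cc5nc6ccccc6nc5c43)c3ccccc32)cc1`, likewise reaches only a limit; compound 3 gives > 50000 nM in this assay.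

Compound 3 thus stands at the limit, as compound 1 does (the limit of > 50000 nM in this assay, at which 2 of the 3 values shown sit). Compound 4, `COc1cc(-n2nncc2CN2C(=O)C3(C(C#N)=C(N)Oc4c(N)cc5nc6ccccc6nc5c43)c3ccccc32)c(OC)cc1Cl`, differs from compound 3 by 4-chloro-2,5-dimethoxyphenyl in place of 4-ethoxyphenyl on an aromatic nitrogen. Among the measured compounds shown here, the one measured step, an at least 1.1-fold lower number from compound 1 to compound 2 (0.04 log units; that floor lies within the scatter), changes a group at the same position but a different pair of groups, and sits within the scatter, so it offers little guidance. For the measured compounds named here, no measured step bears directly on this change. Compound 4 is therefore expected to stay near the limit in this assay. The expected step is a step that the limit leaves unreadable from compound 3 to compound 4, none beyond the scatter. The estimate for compound 4 is 60000 nM, between 25000 nM and 150000 nM.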

Compound 4, half-maximal inhibitory concentration: > 50000 nM
Compound 4 was reported as a limit; the forecaster's own chance of this, stated with the estimate: 75%; the middle value lies beyond the limit too.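

Compound 3 and compound 4 both reach only a limit, so no step can be read between them: the limit of > 50000 nM in this assay, at which 3 of the 4 values shown sit. The compounds shown leave open how 4-ethoxyphenyl and 4-chloro-2,5-dimethoxyphenyl compare in this assay.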